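Replacing the Alkyne-Bound Group of Compound 2

The compounds below may be only part of what the source reports. "The series", "measured", "known", "first", "only" and "open" are said of these compounds alone.

Measured compounds:
Compound 1, `Cc1ccc(-c2nc3ccc(N4CCN(C)CC4)cc3[nH]2)cc1C#Cc1cnc(NC2CC2)nc1`, in a functional assay on KU812 cells for inhibition, with KU812 cell line (Homo sapiens) as the target, read by MTT assay, with a stated time of 72 h (a higher number here means a weaker inhibitor, a lower number a stronger inhibitor), gives 0.4 nM.
Compound 2, `Cc1ccc(C(=O)Nc2ccc3c(c2)C(F)(F)C[C@H]3N2CCN(C)CC2)cc1C#Cc1cnc(NC2CC2)nc1`, in this assay gives 5.2 nM.

Of the two measured compounds, compound 2 stands at the higher number; compound 1 sits at a lower number, and the gap between them lies beyond the usual scatter. Among the compounds with values here, no step between measured compounds that differ in a single place is available, so the effect of any one change cannot be read directly from these two.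

Compound 3, `Cc1ccc(C(=O)Nc2ccc3c(c2)C(F)(F)C[C@H]3N2CCN(C)CC2)cc1C#Cc1cnc2cccnn12`, keeps the core of compound 2 and changes only the end of the alkyne: a group of 9 heavy atoms (6 carbon, 3 nitrogen; one five-membered aromatic ring with 2 hetero atoms, one six-membered aromatic ring with 2 hetero atoms) in place of a group of 10 heavy atoms (7 carbon, 3 nitrogen; one three-membered non-aromatic ring of carbon only, one six-membered aromatic ring with 2 hetero atoms), on a triple-bonded carbon. The amide, the difluorinated ring system and the methylpiperazine are untouched.

Within the data shown here, with no paired step to lean on, the expectation rests on the shared scaffold of compound 2 and on the modest size of the exchange. The estimate is that compound 3 is expected to sit at a somewhat lower number than compound 2, a step of a 1.7-fold lower number from compound 2 to compound 3 (0.24 log units; within the scatter), close to the edge of the scatter. Compound 3 is therefore expected to give about 3 nM in this assay, estimated to fall between 0.8 nM and 15 nM.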

Compound 3, half-maximal inhibitory concentration: 2.7 nM
Estimate against measurement, compound 3: 1.1-fold (0.05 log units) above; low and high end bracket the measured number.
By their numbers in this assay, from the lowest: compound 1; then compounds 3 and 2 (each within the scatter of the next).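

In this assay, the exchange on the triple-bonded carbon gives a 1.9-fold lower number from compound 2 to compound 3 (0.28 log units; within the scatter), so replacing the 2-(cyclopropylamino)pyrimidin-5-yl group with the new two-ring group leaves the reading within the usual scatter. The entering group has no hydrogen-bond donor and no three-membered ring, yet compound 3 gives 2.7 nM in this assay; on this core, then, neither the donor nor the cyclopropyl ring of the leaving group is needed for a reading in this range. No measurement of any property of these two groups bears on this result, and the numbers alone do not show why the two groups read alike.

It remains open whether the same exchange would read alike on the core of compound 1, which carries the 2-(cyclopropylamino)pyrimidin-5-yl group on its alkyne and has no counterpart with the new group among the compounds shown. Also open, from the compounds shown here alone, is how simpler groups on the same triple-bonded carbon would read, such as a 2-aminopyrimidin-5-yl group with a plain amine in place of the cyclopropylamino group, or an unsubstituted phenyl ring.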